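The compounds below may be only part of what the source reports. "The series", "measured", "known", "first", "only" and "open" are said of these compounds alone.

Compound 1 `CC1(C)CC(NC(=O)Nc2ccccc2)c2cc(F)ccc2O1` sets the starting point: in a functional assay (aorta) with Rattus norvegicus as the target (a higher number here means that more compound is needed for the effect, a lower number that less compound is needed), compound 1 gives 17100 nM. Compound 2 `Cc1ccc(NC(=O)NC2CC(C)(C)Oc3ccc(F)cc32)cc1` carries a methyl in place of a hydrogen on an aromatic carbon. In this assay compound 2 gives only a limit, > 30000 nM, and no number. The step from compound 1 to compound 2 is accordingly known only as a floor, an at least 1.7-fold higher number from compound 1 to compound 2 (0.24 log units; that floor lies within the scatter), and that floor sits within the usual scatter. Compound 2 thus stands at the limit of this assay (the limit of > 30000 nM in this assay, at which 1 of the 2 values shown sits), with no measured value of its own. Compound 3 `CC1(C)CC(NC(=O)Nc2ccc(Cl)cc2)c2cc(F)ccc2O1` differs from compound 2 in one place: chloro in place of methyl on an aromatic carbon. Within the data shown here, no measured step exchanges one of these two groups for the other. Among the measured compounds shown here, the only measured step, the one from compound 1 to compound 2, places a methyl on that aromatic carbon and yields a floor within the scatter. An exchange of chloro for methyl on the same aromatic carbon is therefore expected to shift this assay by no more than the scatter, with a fair chance that compound 3 again returns only a limit. The step from compound 2 to compound 3 is estimated as an at least 1.2-fold lower number from compound 2 to compound 3 (0.07 log units; that floor lies within the scatter). Compound 3 is expected to give about 25000 nM in this assay, within 8000 nM to 70000 nM.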

Compound 3, half-maximal effective concentration: > 30000 nM
Compound 3 gave a limit, no number; the forecaster's own chance of this, stated with the estimate: 55%; middle value at least 1.2-fold (0.07 log units) away from the limit.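

In this assay compound 3 gives > 30000 nM, which is a limit of the assay and not a number, so a second group on this aromatic carbon, para to a large group, ends at the same limit as methyl. Chloro in place of hydrogen on that carbon gives an at least 1.7-fold higher number from compound 1 to compound 3 (0.24 log units; that floor lies within the scatter), the same floor as the methyl step, and neither floor reaches beyond the scatter, so neither group is shown to make a real difference against the unsubstituted phenyl of compound 1. The exchange of methyl for chloro itself cannot be read, and all that can be said is that compound 2 and compound 3 sit at one shared limit: the limit of > 30000 nM in this assay, at which 2 of the 3 values shown sit.

As far as these compounds go, how far compound 2 and compound 3 lie past that limit stays open, and with it whether methyl and chloro differ at all on this carbon. Also open, from the compounds shown here alone, is whether a methoxy, an amine or a carboxylic acid on the same aromatic carbon would return a measured number in this assay, and on which side of compound 1 such a number would fall.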